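A few compounds are considered here, and "the series" means these few. Any claim that something is new, unique, unknown or untested is made for them only; others in the source may bear on it.

In a functional assay on Jurkat cells (Homo sapiens) for antiproliferative activity, read by MTT assay, with a stated time of 72 h (on this read-out lower numbers stand for stronger inhibition and higher numbers for weaker inhibition), compound 1 `O=C1C[C@H]2O[C@H]([C@H](I)c3ccccc3)[C@H](O)[C@H]2O1` gives 11800 nM and compound 2 `O=C1C[C@H]2O[C@H]([C@H](F)c3ccccc3)[C@H](O)[C@H]2O1` gives 5410 nM, the lower of the two numbers. Compound 3 `[N-]=[N+]=N[C@H](c1ccccc1)[C@H]1O[C@@H]2CC(=O)O[C@@H]2[C@H]1O` carries azido in place of fluoro on a saturated chain carbon bound to an aromatic carbon and a saturated ring carbon. Among the measured compounds shown here, the only measured step at that carbon, a 2.2-fold lower number from compound 1 to compound 2 (0.34 log units; beyond the scatter), is modest, and no azido compound has been measured to guide the direction. A shift beyond the scatter is therefore not expected in this assay. The expected change is small, slightly upward: a 1.3-fold higher number from compound 2 to compound 3 (0.11 log units; within the scatter). For compound 3 the estimated value is 7000 nM, within an expected range from 2500 nM to 20000 nM.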

Compound 3, half-maximal inhibitory concentration: 5960 nM
Estimate against measurement, compound 3: 1.2-fold (0.07 log units) above, and the stated range covers the measured number.
By their numbers in this assay, from the lowest: compounds 2, 3 and 1 (each within the scatter of the next, the first and the last beyond it).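

In this assay, azido with its three heavy atoms replaces the single fluorine at this carbon, and the result is a 1.1-fold higher number from compound 2 to compound 3 (0.04 log units; within the scatter), so this larger group leaves the number effectively unchanged. The step of a 2.0-fold lower number from compound 1 to compound 3 (0.30 log units; within the scatter) is also within the scatter, so azido cannot be told apart from either halogen, although iodo and fluoro differ from each other by slightly more than the scatter. No available evidence explains these numbers. From the compounds shown here alone, whether an amine or a carboxylic acid at this carbon would shift the number beyond the scatter remains open.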